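A few compounds are considered here, and "the series" means these few. Any claim that something is new, unique, unknown or untested is made for them only; others in the source may bear on it.

Compound 1 `COc1cccc(-c2ccc(S(=O)(=O)Nc3cc(N4C[C@@H](C)N[C@@H](C)C4)ccc3OC)cc2)c1`: 1 in a functional assay for agonist activity at growth hormone secretagogue receptor type 1 (Homo sapiens), read by FLIPR; on this read-out lower numbers stand for smaller maximal responses and higher numbers for larger maximal responses.
Compound 2 `COc1ccc(N2C[C@@H](C)N[C@@H](C)C2)cc1NS(=O)(=O)c1ccc(-c2cncnc2)cc1`: 0.6 in this assay.

Compound 2 is the lower of the two, standing a number 0.40 lower from compound 1 to compound 2 (beyond the scatter). Compound 3 `COc1ccc(N2C[C@@H](C)N[C@@H](C)C2)cc1NS(=O)(=O)c1ccc(Oc2ccccc2)cc1` is made from compound 2 by the change (phenoxy in place of pyrimidin-5-yl on an aromatic carbon). For the measured compounds named here, the only step that speaks to this is the one from compound 1 to compound 2, where a six-membered carbon-only ring gave way to pyrimidin-5-yl and the response fell by that large amount. Bringing back a carbon-only ring, now as phenoxy, is expected to recover much of that: an expected rise a number 0.25 higher from compound 2 to compound 3 (beyond the scatter). Compound 3 is therefore estimated at 0.85, within 0.6 to 1.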

Compound 3, intrinsic activity: the largest response reached, as a fraction of the reference agonist's: 0.9
Estimate against measurement, compound 3: 0.050 below; low and high end bracket the measured number.
By their numbers in this assay, from the lowest: compound 2; then compounds 3 and 1 (each within the scatter of the next).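

In this assay, phenoxy in place of pyrimidin-5-yl, at this place para to a large group, gives a number 0.30 higher from compound 2 to compound 3 (beyond the scatter). Phenoxy in place of 3-methoxyphenyl gives a number 0.10 lower from compound 1 to compound 3 (within the scatter), so these two groups cannot be told apart here, although the change in their attachment and substituent is clear from their names. Both groups with a carbon-only aromatic ring therefore stand clear of pyrimidin-5-yl in these three compounds.

No measurement shown here bears on the reason for these steps. As far as these compounds go, whether this place needs an aromatic ring at all remains open, and a group such as an amine or a longer alkyl chain would test that.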